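Tetrazole to methylsulfanylmethyl on the alkoxy chain

The compounds below may be only part of what the source reports. "The series", "measured", "known", "first", "only" and "open" are said of these compounds alone.

Compound 2 `CCc1cc(C(C)=O)c(O)cc1OCCCCCC(C)(C)c1nnn(C)n1` stands highest of the two numbers in an assay on isolated protein for binding affinity to leukotriene B4 receptor 1 (Homo sapiens), tested at 1 uM (on this read-out higher numbers stand for more inhibition at the one concentration tested (going by the name of the read-out) and lower numbers for less inhibition), giving 66%; compound 1 `CCc1cc(C(C)=O)c(O)cc1OCCCCCCC(C)(C)C#N` gives 30%. Among the compounds with values here, the single measured step, a number 36 percentage points higher from compound 1 to compound 2 (beyond the scatter), bears on the next change. Within the data shown here, compound 3 `CCc1cc(C(C)=O)c(O)cc1OCCCCCCSC` differs from compound 2 by (methylsulfanyl)methyl in place of 1-methyl-1-(2-methyl-2H-tetrazol-5-yl)ethyl on a saturated chain carbon, five bonds along the chain from an oxygen on an aromatic ring, so the group whose entry gave that large rise now leaves, and the incoming group has no counterpart among the measured compounds. A drop beyond the scatter is expected, a number 41 percentage points lower from compound 2 to compound 3 (beyond the scatter), with wide uncertainty. Compound 3 is therefore estimated at 25% in this assay, within 5% to 50%.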

Compound 3, a percentage reported as inhibition, at one concentration (the size of the read-out at that concentration, not a potency): 14%
Compound 3: the middle estimate sits 11 percentage points above what was measured; the measured number falls inside the stated range.
By their numbers in this assay, from the lowest: compound 3; then compound 1; then compound 2.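

In this assay the end of this chain sets the read-out: (methylsulfanyl)methyl in place of 1-methyl-1-(2-methyl-2H-tetrazol-5-yl)ethyl gives a number 52 percentage points lower from compound 2 to compound 3 (beyond the scatter) and loses more than the earlier rise had gained. Methylsulfanyl in place of 1-cyano-1-methylethyl gives a number 16 percentage points lower from compound 1 to compound 3 (beyond the scatter), so neither end without a ring reaches compound 2. Nothing measured here accounts for these steps.

Still open, from the compounds shown here alone, is whether the tetrazole ring alone carries the gain or needs the 1-methylethyl carbon that holds it. A carboxylic acid or an amide at this place could show whether another end matches compound 2.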